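Fluoro to bromo on the pendant aryl ring

A few compounds are considered here, and "the series" means these few. Any claim that something is new, unique, unknown or untested is made for them only; others in the source may bear on it.

Measured compounds:
- compound 1, `O=C(Nc1ccc(Oc2ccnc3[nH]ccc23)cc1)c1cn(-c2ccc(F)c(Cl)c2)c2ccccc2c1=O`: 1510 nM
- compound 2, `Cn1ccc2c(Oc3ccc(NC(=O)c4cn(-c5ccc(F)cc5)c5ccccc5c4=O)cc3F)ccnc21`: "not determined" (no result reported)

The study concerns a functional assay on MCF7 cells (Homo sapiens) for inhibition, read by MTT assay, with a stated time of 72 h; a lower number here means a stronger inhibitor, a higher number a weaker inhibitor. Compound 1 gives 1510 nM in this assay, whereas for compound 2 no result is reported, so compound 2 stands nowhere on the numbers shown and offers no value of its own against which a neighbour can be placed.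

Compound 3, `Cn1ccc2c(Oc3ccc(NC(=O)c4cn(-c5ccc(Br)cc5)c5ccccc5c4=O)cc3F)ccnc21`, differs from compound 2 by bromo in place of fluoro on an aromatic carbon, para to a large group as described. Going by the values given here, no step between two measured compounds is available for this kind of change, so the size and direction of the step from compound 2 to compound 3 cannot be read from the data; a step within the usual scatter is as plausible as a modest one in either direction.

Resting only on the single number from compound 1 and the shared core, compound 3 is expected to give about 2000 nM, with a range from 500 nM to 8000 nM.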

Compound 3, half-maximal inhibitory concentration: 1830 nM
Compound 3: middle estimate off by 1.1-fold (0.04 log units), on the high side; measured number inside the range.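

No step can be read from compound 2 to compound 3, as compound 2 has no number to set against compound 3 at 1830 nM. On these data alone, what 4-fluorophenyl to 4-bromophenyl does in this assay stays open. Nothing shown bears on the result.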